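The source may hold more compounds than are shown below. What is called first, only, known or untested is meant among the compounds shown, and "the series" means these compounds.

Working notes on the series. The shared core of compound 1 `Brc1cccc2c1nnn2Cc1ccccc1` carries a benzyl group with nothing on its six-membered ring; in an ADME assay on microsomes from liver (Mus musculus, strain NMRI) for metabolic stability, tested at 2.5 uM (a higher number here means faster removal of the compound, a lower number slower removal), compound 1 gives 2.3 mL/min/g. Compound 2 `Fc1ccc(Cn2nnc3c(Br)cccc32)cc1` adds a fluoro, and in this assay compound 2 gives 1 mL/min/g. Compound 3 `Clc1ccc(Cn2nnc3c(Br)cccc32)cc1` carries a chloro instead, and in this assay compound 3 gives 2 mL/min/g. Among the three numbers compound 3 stands close to compound 1, the change being a 1.2-fold lower number from compound 1 to compound 3 (0.06 log units; within the scatter), and further from compound 2, the change being a 2.0-fold higher number from compound 2 to compound 3 (0.30 log units; within the scatter), so neither gap leaves the scatter; only a 2.3-fold lower number from compound 1 to compound 2 (0.36 log units; beyond the scatter) does.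

Compound 4 `Brc1ccc(Cn2nnc3c(Br)cccc32)cc1` is the next member; the change from compound 3 is bromo in place of chloro on an aromatic carbon. Among the measured compounds shown here, two measured steps bear on a halogen swap at this place: a 2.0-fold higher number from compound 2 to compound 3 (0.30 log units; within the scatter) and a 1.2-fold lower number from compound 1 to compound 3 (0.06 log units; within the scatter). Both are within the scatter, so a change from chloro to bromo on the same aromatic carbon is expected to give at most a small step in this assay, with no clear direction. The estimated step for compound 4 is therefore a 1.1-fold higher number from compound 3 to compound 4 (0.02 log units; within the scatter), essentially flat. Compound 4 is expected to give 2.1 mL/min/g in this assay, with a range from 1 mL/min/g to 4.2 mL/min/g.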

Compound 4, intrinsic clearance in a liver preparation (reported as CLH), per the amount of preparation that the assay uses: 2.6 mL/min/g
Compound 4: middle estimate off by 1.2-fold (0.09 log units), on the low side; the measured number falls inside the stated range.
By their numbers in this assay, from the lowest: compounds 2, 3, 1 and 4 (each within the scatter of the next, the first and the last beyond it).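

On this aromatic carbon, para to a large group, bromo in place of chloro gives a 1.3-fold higher number from compound 3 to compound 4 (0.11 log units; within the scatter) in this assay and bromo in place of hydrogen gives a 1.1-fold higher number from compound 1 to compound 4 (0.05 log units; within the scatter) in the same read-out, so neither the chloro nor the bromo compound separates from the compound with the unsubstituted benzyl group. The new point concerns fluoro: a 2.6-fold higher number from compound 2 to compound 4 (0.41 log units; beyond the scatter) joins a 2.3-fold lower number from compound 1 to compound 2 (0.36 log units; beyond the scatter) as a second step beyond the scatter, which sets compound 2 apart from both compound 1 and compound 4, although compound 3 goes against a clean split, with a 2.0-fold higher number from compound 2 to compound 3 (0.30 log units; within the scatter) still within the scatter. Nothing available explains why the fluoro compound stands apart from compound 1 and compound 4.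

Open, going by these compounds, is how an amine, a carboxylic acid or a methoxy group on this same aromatic carbon would read in this assay in comparison with the halogens. Also open, on these data alone, is whether the gap between the fluoro and bromo compounds persists when the bromo on the shared core gives way to another group such as a nitrile.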